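Bromo for Chloro on the Pendant Phenyl Ring

The source may hold more compounds than are shown below. What is called first, only, known or untested is meant among the compounds shown, and "the series" means these compounds.

Compound 1 `O=C(Nc1ccc(Oc2ccnc3[nH]ccc23)cc1)c1cc2cccnc2n(-c2ccc(Br)cc2)c1=O`: 280 nM
Compound 2 `Cn1ccc2c(Oc3ccc(NC(=O)c4cc5cccnc5n(-c5ccc(Cl)cc5)c4=O)cc3)ccnc21`: 630 nM

Both numbers come from a functional assay on A549 cells (Homo sapiens) for antiproliferative activity, read by MTT assay, with a stated time of 72 h; a higher number here means a weaker inhibitor, a lower number a stronger inhibitor. Compound 2 stands at the higher of the two, with compound 1 giving a number lower by a margin beyond the usual scatter. Compound 3 `Cn1ccc2c(Oc3ccc(NC(=O)c4cc5cccnc5n(-c5ccc(Br)cc5)c4=O)cc3)ccnc21` has not yet been measured. It differs from compound 2 in one place: bromo in place of chloro on an aromatic carbon. Among the compounds with values here, no step between two measured compounds that differ in a single place is available, and compound 1 differs from compound 3 elsewhere, so its value cannot be read as that step. Exchanging one halogen for another here is expected to move the number little, if at all, and no step beyond the scatter is expected. The step from compound 2 to compound 3 in this assay is estimated as a 1.3-fold lower number from compound 2 to compound 3 (0.10 log units; within the scatter). Compound 3 is therefore estimated at 500 nM, with a range from 220 nM to 1100 nM.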

Compound 3, half-maximal inhibitory concentration: 680 nM
Compound 3: middle estimate off by 1.4-fold (0.13 log units), on the low side; low and high end bracket the measured number.
By their numbers in this assay, from the lowest: compound 1; then compounds 2 and 3 (each within the scatter of the next).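

In this assay, the change from 4-chlorophenyl to 4-bromophenyl gives a 1.1-fold higher number from compound 2 to compound 3 (0.03 log units; within the scatter), so the two halogens cannot be told apart at this place on the pendant ring. Compound 3 also allows a single-place comparison at the other end of the molecule: methyl in place of hydrogen on an aromatic nitrogen gives a 2.4-fold higher number from compound 1 to compound 3 (0.39 log units; beyond the scatter), a modest step but one beyond the scatter, unlike the halogen exchange. Nothing measured here offers an explanation for either step.

On these data alone, it remains open whether a methoxy group or an amine on that same aromatic carbon would stay as close to these values as bromo does. As far as these compounds go, it is also open whether a longer chain than methyl on the aromatic nitrogen would extend the step seen there.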